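This account rests on a few compounds, and the source may have more. Where it says the series, first, only, none or still open, it means among the compounds named here.

Measured compounds:
Compound 1, `CCn1c(/N=C/c2ccc(F)cc2)c(C#N)sc1=S`, gives 0.00059 nM in an assay on HEK293 cells for displacement of a labelled ligand from adenosine receptor A1 (Homo sapiens), read by scintillation counting, with a stated time of 60 min; a lower number here means a stronger inhibitor, a higher number a weaker inhibitor.
Compound 2, `CCCn1c(/N=C/c2ccc(F)cc2)c(C#N)sc1=S`, gives 102 nM in this assay.
Compound 3, `CCCn1c(/N=C/c2ccc(Cl)cc2)c(C#N)sc1=S`, gives 2.32 nM in this assay.

Compound 1 and compound 2 share a core and differ in one place: methyl in place of hydrogen on a saturated chain carbon, two bonds along the chain from an aromatic nitrogen. That change brought a 170000-fold higher number from compound 1 to compound 2 (5.24 log units; beyond the scatter). Compound 2 and compound 3 also differ in one place, the halogen on the aromatic ring, and here a 44-fold lower number from compound 2 to compound 3 (1.64 log units; beyond the scatter). How compound 1 and compound 3 differ is not broken down here, since they differ in more than one place; their two numbers show that compound 1 sits far lower than compound 3.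

Compound 4, `CCCCn1c(/N=C/c2ccc(Cl)cc2)c(C#N)sc1=S`, has not yet been measured. Against compound 3 it differs by methyl in place of hydrogen on a saturated chain carbon, three bonds along the chain from an aromatic nitrogen. Among the compounds with values here, this is the same kind of change as the one from compound 1 to compound 2, but not the same: there the added methyl sat two bonds along the chain from the aromatic nitrogen, here it sits three bonds along. Within the data shown here, only one earlier example of this kind of change exists, and it rests on compound 1, whose number stands far apart from the other two. Compound 4 is therefore expected to give a weaker result than compound 3, with a step of a 4.3-fold higher number from compound 3 to compound 4 (0.63 log units; beyond the scatter), smaller than the earlier one because a 170000-fold higher number from compound 1 to compound 2 (5.24 log units; beyond the scatter) stood on a single pair. The estimate for compound 4 in this assay is 10 nM, expected to fall between 1.5 nM and 70 nM.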

Compound 4, inhibition constant: 24600 nM
For compound 4 the middle estimate is 2500-fold (3.39 log units) below the measured one, and the stated range ends below it.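

Extending the chain by one more carbon, from propyl to butyl, brought an 11000-fold higher number from compound 3 to compound 4 (4.03 log units; beyond the scatter) in this assay, so the number rose here just as it did when ethyl became propyl. The direction of the change carried over from one core to the other, but its size did not: the same change on two cores in this assay, a 170000-fold higher number (5.24 log units; beyond the scatter) from compound 1 to compound 2 and an 11000-fold higher number (4.03 log units; beyond the scatter) from compound 3 to compound 4, 16-fold (1.21 log units) apart, beyond the scatter of two such steps

Within the data shown here, with only two pairs, which differ both in the halogen on the aromatic ring and in where the added methyl sits on the chain, these steps cannot tell which of those two differences sets the gap, and they offer no size that could safely be carried to a further core.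

The compounds shown leave open whether the number keeps rising with a longer chain such as pentyl, and whether a chain carrying an amine or a hydroxyl group would behave like these plain chains. They also leave open what butyl does with fluoro on the aromatic ring and what ethyl does with chloro, the two pairings that would separate the effect of the halogen from that of the chain length.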